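Tripeptide amide series: aryl cap variations and permeability

This account rests on a few compounds, and the source may have more. Where it says the series, first, only, none or still open, it means among the compounds named here.

In an ADME assay for permeability, using PAMPA (a higher number here means that the compound crosses the layer faster, a lower number that the compound crosses the layer more slowly), compound 1 `CCCC[C@H](NC(=O)[C@H](CCCCN)NC(=O)[C@H](CCCNC(=N)N)NC(=O)/C=C/c1ccccc1)C(N)=O` gives 1.26 10^-6 cm/s. Compound 2 `CCCC[C@H](NC(=O)[C@H](CCCCN)NC(=O)[C@H](CCCNC(=N)N)NC(=O)c1ccc(/C=C/C(N)=O)cc1)C(N)=O` stands without a number in this assay: it was reported as "impermeable" (no number reported), and compound 3 `CCCC[C@H](NC(=O)[C@H](CCCCN)NC(=O)[C@H](CCCNC(=N)N)NC(=O)c1ccc(/C=C2\NC(=S)N(c3ccccc3)C2=O)cc1)C(N)=O` was likewise reported as "impermeable" (no number reported). Within the data shown here, no step between two measured compounds is available, so the change from compound 2 to compound 4 `C=CCN1C(=O)/C(=C/c2ccc(C(=O)N[C@@H](CCCNC(=N)N)C(=O)N[C@@H](CCCCN)C(=O)N[C@@H](CCCC)C(N)=O)cc2)SC1=S` can be judged only from the structures. The change is a group of 11 heavy atoms (7 carbon, 1 nitrogen, 1 oxygen, 2 sulfur; one five-membered non-aromatic ring with 2 hetero atoms) in place of a group of 5 heavy atoms (3 carbon, 1 nitrogen, 1 oxygen; no ring), on an aromatic carbon, a ring-bearing group in place of a group without a ring, on an aromatic carbon, para to a large group. Compound 3 carries a comparably large ring-bearing group at that place and was reported impermeable, so no rise beyond the scatter is expected for compound 4; a reading near the floor of this assay, or again only a report of impermeability, is expected. Compound 4 is estimated at 0.3 10^-6 cm/s, with a range from 0.05 10^-6 cm/s to 1.5 10^-6 cm/s.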

Compound 4, apparent permeability: 0.42 10^-6 cm/s
The estimate for compound 4 lay 1.4-fold (0.15 log units) below the measured number; measured number inside the range.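

No step can be read between compound 2 and compound 4: compound 2 was reported only as impermeable, without a number. The compounds shown leave open how far the group at that place moves the reading in this assay. No measured evidence bears on this result.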